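The source may hold more compounds than are shown below. What is called first, only, known or untested is meant among the compounds shown, and "the series" means these compounds.

Compound 1 `CCCCCCC[C@H]1C[C@H](Cl)CCN1S(=O)(=O)c1ccc(C)cc1`: 54000 nM
Compound 2 `Cc1ccc(S(=O)(=O)N2CC[C@@H](Cl)C[C@@H]2c2ccccc2)cc1`: 37000 nM
Compound 3 `Cc1ccc(S(=O)(=O)N2CC[C@@H](Br)C[C@@H]2CC(C)C)cc1`: 14000 nM

Three compounds on the shared core have numbers in a functional assay on WiDr cells (Homo sapiens) for antiproliferative activity, read by sulforhodamine B assay, with a stated time of 48 h; a lower number here means a stronger inhibitor of growth, a higher number a weaker inhibitor of growth. Compound 2 stands second highest of the three: the gap to compound 1 is within the scatter, the gap to compound 3 is beyond it. Among the measured compounds shown here, the only single-place step measured, a 1.5-fold lower number from compound 1 to compound 2 (0.16 log units; within the scatter), is phenyl in place of heptyl on a saturated ring carbon and lies within the scatter. Compound 4 `Cc1ccc(S(=O)(=O)N2CC[C@@H](Br)C[C@@H]2c2ccccc2)cc1` differs from compound 2 by bromo in place of chloro on a saturated ring carbon. For the measured compounds named here, no measured pair isolates this halogen exchange; compound 3 carries bromo but also a different group on the other ring carbon, so its value cannot separate the two changes. The expected step is therefore a 1.2-fold lower number from compound 2 to compound 4 (0.09 log units; within the scatter), none beyond the scatter. Compound 4 is estimated to give 30000 nM in this assay, range 12000 nM to 75000 nM.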

Compound 4, concentration for 50% growth inhibition: 36000 nM
Beside the measured number, compound 4's estimate is 1.2-fold (0.08 log units) below it, within the range that was stated.
By their numbers in this assay, from the lowest: compound 3; then compounds 4, 2 and 1 (each within the scatter of the next).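

In this assay with phenyl on the ring, bromo in place of chloro gives a 1.0-fold lower number from compound 2 to compound 4 (0.01 log units; within the scatter), so this halogen exchange on the saturated ring carbon does not separate the two compounds. Among the compounds shown here, with bromo held fixed, phenyl in place of isobutyl gives a 2.6-fold higher number from compound 3 to compound 4 (0.41 log units; beyond the scatter) and is the first single-place step beyond the scatter, so here the group on the other ring carbon moves the number more than the halogen does. No measurement to hand accounts for either step.

Going by these compounds, whether a hydroxyl or an amine on the halogen-bearing carbon would shift growth inhibition remains open. Also open, on these data alone, is whether chloro and bromo stay equivalent with isobutyl or heptyl on the ring.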